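Replacing the chlorophenyl ester aryl group with fluorophenyl

The compounds below may be only part of what the source reports. "The series", "measured", "known", "first", "only" and "open" are said of these compounds alone.

Measured so far:
Compound 1 `COc1cc2c(c(O)c1C(=O)/C=C/c1ccc(OC(=O)c3cccc(Cl)c3)cc1)CCC(C)(C)O2` gives > 30000 nM in an assay on HEK293T cells for inhibition of nuclear factor NF-kappa-B complex (Homo sapiens), read by a luciferase reporter; on this read-out lower numbers stand for stronger inhibition and higher numbers for weaker inhibition.
Compound 2 `COc1cc2c(c(O)c1C(=O)/C=C/c1ccc(OC(=O)c3ccc(Cl)nc3)cc1)CCC(C)(C)O2` gives > 30000 nM in this assay.

Compound 1 stands at the limit of this assay: its value is a limit, not a number. The same holds for compound 2, whose value is also a limit. The step that the two limits leave unreadable from compound 1 to compound 2 is therefore unreadable, since the limit of > 30000 nM in this assay, at which 2 of the 2 values shown sit, is where both values sit.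

Compound 3 `COc1cc2c(c(O)c1C(=O)/C=C/c1ccc(OC(=O)c3ccccc3F)cc1)CCC(C)(C)O2` differs from compound 1 by 2-fluorophenyl in place of 3-chlorophenyl on a carbonyl carbon. Among the measured compounds shown here, the only measured step, from compound 1 to compound 2, changes the same aryl group on that carbonyl carbon and gives no readable size, so no direction can be read from it. The expectation for compound 3 is that it too remains near or beyond the limit, with the step that the limit leaves unreadable from compound 1 to compound 3 expected to be unreadable. Compound 3 is estimated at 40000 nM in this assay, within a range from 10000 nM to 150000 nM.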

Compound 3, half-maximal inhibitory concentration: > 30000 nM
Compound 3: only a limit was reported; the forecaster's own chance of this, stated with the estimate: 80%; the middle value does not contradict the limit.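

Among the compounds shown here, no step among compound 1, compound 2 and compound 3 can be read, because all three values are limits and not numbers: the limit of > 30000 nM in this assay, at which 3 of the 3 values shown sit.

The compounds shown leave open whether any aryl group on this carbonyl carbon gives a measurable value in this assay.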